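The source may hold more compounds than are shown below. What is called first, only, known or untested is meant among the compounds shown, and "the series" means these compounds.

Compounds measured so far in an ADME assay on Vero cells (Chlorocebus sabaeus) for cytotoxicity, read by CCK-8 assay, with a stated time of 72 h; a lower number here means a stronger inhibitor, a higher number a weaker inhibitor:

compound 1, `Cc1ccn2nc(C)c(C(=O)NCc3ccc(N4CCCCC4)cc3)c2c1` — > 100000 nM
compound 2, `Cc1ccn2nc(C)c(C(=O)NCc3ccc(N4CCN(c5ccc(F)cc5)CC4)cc3)c2c1` — > 100000 nM
compound 3, `Cc1nn2c(C)cccc2c1C(=O)NCc1ccc(N2CCC(c3ccc(OC(F)(F)F)cc3)CC2)cc1` — "not determined" (no result reported)

The value for compound 1 is a limit of the assay and not a number. The value for compound 2 is likewise a limit. Compound 3 has no result in this assay, so there is no single number to place it by; the two further values shown both sit at the limit of > 100000 nM in this assay, at which 2 of the 3 values shown sit, and that is all the measured compounds tell about where compound 3 stands.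

Compound 4, `Cc1nn2ccc(Cl)cc2c1C(=O)NCc1ccc(N2CCC(c3ccc(OC(F)(F)F)cc3)CC2)cc1`, differs from compound 3 in one place: a group of 11 heavy atoms (8 carbon, 2 nitrogen, 1 chlorine; one five-membered aromatic ring with 2 hetero atoms, one six-membered aromatic ring with 1 hetero atom) in place of a group of 11 heavy atoms (9 carbon, 2 nitrogen; one five-membered aromatic ring with 2 hetero atoms, one six-membered aromatic ring with 1 hetero atom), on a carbonyl carbon. For the measured compounds named here, no step between two measured compounds is available here, so the size of the change cannot be read from the data; with both measured values sitting at the same limit, there is no direction to carry forward either. The expectation is that compound 4 also gives no number beyond the scatter in this assay, and that it most likely returns a limit once more. Compound 4 is therefore estimated at 100000 nM, with a range from 30000 nM to 300000 nM.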

Compound 4, half-maximal inhibitory concentration: > 100000 nM
Compound 4: a limit, no number (the forecaster's own chance of this, stated with the estimate: 70%); the middle value sits exactly at the limit.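

For the compounds shown here, no step from compound 3 to compound 4 can be read in this assay, as compound 3 has no reported result. Compound 4 gives > 100000 nM, a limit and not a number. The compounds shown leave open whether any substitution changes this read-out at all, with most values at one limit: the limit of > 100000 nM in this assay, at which 3 of the 4 values shown sit.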